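A few compounds are considered here, and "the series" means these few. Any claim that something is new, unique, unknown or untested is made for them only; others in the source may bear on it.

Measured so far in an ADME assay on RAW264.7 cells (Mus musculus) for cytotoxicity, read by MTT assay, with a stated time of 72 h, tested at 50 uM; on this read-out higher numbers stand for a stronger effect at the one concentration tested and lower numbers for a weaker effect:
compound 1 `O=C(Cn1c(=O)oc2cc(Cl)ccc21)Nc1ccccc1` gives 15.8%
compound 2 `O=C(Cn1c(=O)oc2ccccc21)Nc1ccccc1` gives 35.1%
compound 3 `O=C(Cn1c(=O)oc2ccccc21)Nc1ccccn1` gives 20.2%

Compound 1 differs from compound 2 by chloro in place of hydrogen on an aromatic carbon, and this change gave a number 19.3 percentage points lower from compound 2 to compound 1 (beyond the scatter). Compound 3 differs from compound 2 by pyridin-2-yl in place of phenyl on an amide-type nitrogen, with a number 14.9 percentage points lower from compound 2 to compound 3 (beyond the scatter). Compound 1 and compound 3 sit within the scatter of each other.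

Compound 4 `O=C(Cn1c(=O)oc2cc(Cl)ccc21)Nc1ccccn1` is not yet measured. It differs from compound 3 by chloro in place of hydrogen on an aromatic carbon, the same change as from compound 2 to compound 1; among the compounds shown this change occurs in two pairs. In this assay a step of about a number 12.2 percentage points lower from compound 3 to compound 4 (beyond the scatter) is expected, resting on compound 1 and its step of a number 19.3 percentage points lower from compound 2 to compound 1 (beyond the scatter), though a starting number as low as that of compound 3 leaves little room downward. Compound 4 is thus estimated at 8%, between 0% and 22%.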

Compound 4, a percentage reported as inhibition, at one concentration (the size of the read-out at that concentration, not a potency): 33%
For compound 4 the middle estimate is 25 percentage points below the measured one; the whole stated range lies below it.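

In this assay, chloro in place of hydrogen on an aromatic carbon does not carry from one core to the other, giving a number 12.8 percentage points higher from compound 3 to compound 4 (beyond the scatter), against the earlier drop: the same change on two cores in this assay, a number 19.3 percentage points lower (beyond the scatter) from compound 2 to compound 1 and a number 12.8 percentage points higher (beyond the scatter) from compound 3 to compound 4, 32.1 percentage points apart, beyond the scatter of two such steps
Pyridin-2-yl in place of phenyl on an amide-type nitrogen reverses in the same way, giving a number 17.2 percentage points higher from compound 1 to compound 4 (beyond the scatter): the same change on two cores in this assay, a number 14.9 percentage points lower (beyond the scatter) from compound 2 to compound 3 and a number 17.2 percentage points higher (beyond the scatter) from compound 1 to compound 4, 32.1 percentage points apart, beyond the scatter of two such steps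
Within these compounds, the step for each change depends on the group at the other place, so neither step can be transferred as a fixed increment, though the data do not show why this happens or whether it extends beyond this set.

As far as these compounds go, it remains open whether a methoxy or fluoro group on the same aromatic carbon would show the same reversal. The same question stands for a pyridin-3-yl group on the amide-type nitrogen.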